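The compounds below may be only part of what the source reports. "The series", "measured", "known", "first", "only" and "open" are said of these compounds alone.

Measured so far in a functional assay on MKN-45 cells (Homo sapiens) for cytotoxicity, read by MTT assay, with a stated time of 72 h; on this read-out higher numbers stand for weaker inhibition and lower numbers for stronger inhibition:
compound 1 `Cn1ncnc1-c1cc(Oc2ccc(NC(=O)N/N=C/c3ccccc3)cc2F)ccn1`, a limit rather than a number, > 100000 nM.
compound 2 `CN(C)CCn1cnnc1-c1cc(Oc2ccc(NC(=O)N/N=C/c3ccc(F)cc3)cc2F)ccn1`, 1030 nM.
compound 3 `CN(C)CCn1cnnc1-c1cc(Oc2ccc(NC(=O)N/N=C/c3ccc(F)cc3F)cc2F)ccn1`, 810 nM.

Compound 2 holds the higher of the two numbers, and its nearest neighbour is compound 3, reached by a 1.3-fold lower number from compound 2 to compound 3 (0.10 log units; within the scatter). Compound 1 sits at a limit of the assay, not a number: the limit of > 100000 nM in this assay, at which 1 of the 3 values shown sits. Compound 4 `CN(C)CCn1cnnc1-c1cc(Oc2ccc(NC(=O)N/N=C/c3ccc(F)cc3Cl)cc2F)ccn1` differs from compound 2 by chloro in place of hydrogen on an aromatic carbon. Among the compounds with values here, the only measured step that bears on this change is the fluoro in place of hydrogen on an aromatic carbon from compound 2 to compound 3, which stayed within the scatter; a chloro entering in the same way is therefore expected to shift the number only slightly, by a 1.4-fold lower number from compound 2 to compound 4 (0.14 log units; within the scatter). Compound 4 is expected to give 750 nM, in the range 350 nM to 1600 nM.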

Compound 4, half-maximal inhibitory concentration: 870 nM
Beside the measured number, compound 4's estimate is 1.2-fold (0.06 log units) below it; low and high end bracket the measured number.
By their numbers in this assay, from the lowest: compounds 3, 4 and 2 (each within the scatter of the next). At a limit, above all of these: compound 1.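

In this assay, a chloro group on this aromatic carbon, ortho to a large group, stays within the scatter, with a 1.2-fold lower number from compound 2 to compound 4 (0.07 log units; within the scatter). Chloro in place of fluoro at the same carbon also stays within the scatter, with a 1.1-fold higher number from compound 3 to compound 4 (0.03 log units; within the scatter), so among compounds 2, 3 and 4 neither halogen separates from hydrogen or from the other halogen. Nothing measured here bears on why this position responds in this way. The compounds shown leave open whether a methoxy group, a trifluoromethyl group or an amine on this carbon would also stay within the scatter.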